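A few compounds are considered here, and "the series" means these few. Any claim that something is new, unique, unknown or untested is made for them only; others in the source may bear on it.

Measured so far in an assay on CHO cells for displacement of a labelled ligand from 5-hydroxytryptamine receptor 1D (Homo sapiens); on this read-out lower numbers stand for stronger inhibition and higher numbers for weaker inhibition:
compound 1, `CC(C)=CCCN(C)C1CCN(CCCc2c[nH]c3ccc(-n4cnnc4)cc23)CC1`, 2.6 nM
compound 2, `O[C@@H]1Cc2ccccc2[C@H]1NC1CCN(CCCc2c[nH]c3ccc(-n4cnnc4)cc23)CC1`, 6.6 nM
compound 3, `CN(Cc1ccco1)C1CCN(CCCc2c[nH]c3ccc(-n4cnnc4)cc23)CC1`, 9.3 nM

Compound 3 gives the highest number of the three in this assay. Its distance to compound 2 is small: a 1.4-fold higher number from compound 2 to compound 3 (0.15 log units; within the scatter). Its distance to compound 1 is larger: a 3.6-fold higher number from compound 1 to compound 3 (0.55 log units; beyond the scatter).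

The next compound, compound 4, `c1ccc2c(c1)CCC2NCC1CCN(CCCc2c[nH]c3ccc(-n4cnnc4)cc23)CC1`, differs from compound 3 by the change (((2,3-dihydro-1H-inden-1-yl)amino)methyl in place of ((furan-2-yl)methyl)(methyl)amino on a saturated ring carbon). The group that enters resembles the group on compound 2, which carries the hydroxyl on its 2,3-dihydro-1H-inden-1-yl part and lacks the methyl spacer; the step from compound 2 to compound 3 was within the scatter. Among the compounds with values here, the only step that went beyond the scatter, from compound 1 to compound 3, involved a different kind of exchange and does not bear directly on this change. The expectation is therefore a step from compound 3 to compound 4 of no more than modest size, most likely a lower number, the step being a 1.6-fold lower number from compound 3 to compound 4 (0.19 log units; within the scatter). Compound 4 is estimated at 6 nM, with a range from 2 nM to 18 nM.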

Compound 4, half-maximal inhibitory concentration: 1.1 nM
Estimate against measurement, compound 4: 5.5-fold (0.74 log units) above; the measured number lies below the stated range.
By their numbers in this assay, from the lowest: compound 4; then compound 1; then compounds 2 and 3 (each within the scatter of the next).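

In this assay, ((2,3-dihydro-1H-inden-1-yl)amino)methyl on this saturated ring carbon stands clear of all three earlier groups, with an 8.5-fold lower number from compound 3 to compound 4 (0.93 log units; beyond the scatter), a 6.0-fold lower number from compound 2 to compound 4 (0.78 log units; beyond the scatter) and a 2.4-fold lower number from compound 1 to compound 4 (0.37 log units; beyond the scatter), so compound 4 now holds the lowest number in the series. The comparison with compound 2 is the most telling, since both groups carry the 2,3-dihydro-1H-inden-1-yl part, yet the change removes the hydroxyl and adds a methyl spacer, placing the amine nitrogen one carbon away from the ring. Nothing available accounts for the size of these steps.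

The compounds shown leave open whether the lower number follows the methyl spacer, the missing hydroxyl, or both. The plain (2,3-dihydro-1H-inden-1-yl)amino group and the (2-hydroxy-2,3-dihydro-1H-inden-1-yl)aminomethyl group would separate the two, and an ethyl spacer would test the chain length.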